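Methoxycarbonyl to carbamoyl: notes on compound 4

The compounds below may be only part of what the source reports. "The series", "measured", "known", "first", "only" and "open" are said of these compounds alone.

In an ADME assay on HeLa cells (Homo sapiens) for cytotoxicity, read by crystal violet staining, with a stated time of 72 h (a lower number here means that less compound is tolerated, a higher number that more compound is tolerated), compound 1 `COC(=O)c1cc(CCCOc2c(C)cc(-c3noc(C(F)(F)F)n3)cc2C)on1` gives 35400 nM. Within the usual scatter of compound 1 sits compound 3 `CCOC(=O)c1cc(CCCOc2ccc(-c3noc(C(F)(F)F)n3)cc2F)on1` at 60200 nM, so these two numbers cannot be told apart. Compound 2 `CCOC(=O)c1cc(CCCOc2ccc(-c3noc(C(F)(F)F)n3)cc2OC)on1` returns only a limit, > 100000 nM.

Compound 4 `Cc1cc(-c2noc(C(F)(F)F)n2)cc(C)c1OCCCc1cc(C(N)=O)no1` is compound 1 with one change, (amino in place of methoxy on a carbonyl carbon). In words, this is amino in place of methoxy on a carbonyl carbon, which turns methoxycarbonyl into carbamoyl.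

Among the compounds with values here, no measured step covers this change. Within the data shown here, the only step available, an at least 1.6-fold lower number from compound 2 to compound 3 (0.22 log units; that floor lies within the scatter), is fluoro in place of methoxy on an aromatic carbon, which is a different change, and its floor lies within the scatter. It gives no size or direction to carry over, so the expectation starts from compound 1 at 35400 nM and allows for a drift towards the other values of the series. The expected step is a 1.7-fold higher number from compound 1 to compound 4 (0.23 log units; within the scatter), so no shift beyond the scatter is expected in this assay. A reading at the limit of > 100000 nM in this assay, at which 1 of the 3 values shown sits, also remains possible for compound 4.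

For compound 4 the estimated value is 60000 nM, with an expected range of 20000 nM to 100000 nM.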

Compound 4, half-maximal cytotoxic concentration: > 100000 nM
Compound 4 ended at the assay's limit; the forecaster's own chance of this, stated with the estimate: 35%; middle value at least 1.6-fold (0.22 log units) away from the limit.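

Compound 1 and the other esters shown leave this carbonyl carbon untested against any other group, and the change from methoxycarbonyl to carbamoyl supplies the one step at this position in this assay: an at least 2.8-fold higher number from compound 1 to compound 4 (0.45 log units; beyond the scatter). Compound 4 gives > 100000 nM, which is a limit of the assay and not a number. Unlike the only earlier step, whose floor lies within the scatter, this floor lies beyond it, so a single swap of methoxy for amino on the carbonyl carbon is enough to separate two compounds on the same core, though the series now leans on the end of the range: the limit of > 100000 nM in this assay, at which 2 of the 4 values shown sit.

The compounds shown leave open whether a carboxylic acid, a methylamide or a nitrile in place of methoxycarbonyl would read like compound 1 or like compound 4. They also leave open whether carbamoyl in place of ethoxycarbonyl on the cores of compound 2 and compound 3 gives a comparable step, and how much of the step belongs to the amide hydrogen rather than to the loss of the methoxy group.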